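Cyanophenyl change from compound 1 to compound 3

The source may report more compounds than this note shows. Statements on the series, on what has been measured and on what is new or still open speak of the compounds shown alone.

compound 1 `COc1cc2c(Nc3ccc(C#N)cc3)ncnc2cc1OCCCN1CCCCC1` gives 18800 nM
compound 2 `COc1cc2c(Nc3ccc(C#N)cc3)ncnc2cc1OCCCN1CCN(C)CC1` gives 13000 nM
compound 3 `COc1cc2c(Nc3ccccc3C#N)ncnc2cc1OCCCN1CCCCC1` is not yet measured

In a functional assay on SH-SY5Y cells (Homo sapiens) for antiproliferative activity, read by MTT assay, with a stated time of 72 h (a lower number here means a stronger inhibitor, a higher number a weaker inhibitor), compound 1 gives 18800 nM and has one measured neighbour, with the step being a 1.4-fold lower number from compound 1 to compound 2 (0.16 log units; within the scatter). The change to compound 3 is 2-cyanophenyl in place of 4-cyanophenyl on a nitrogen on an aromatic ring. Within the data shown here, that measured step sits on a saturated chain carbon, so no measured step covers the nitrogen on an aromatic ring, and the data give no direction for this change. No step beyond the scatter is expected, and the estimated step is a 1.1-fold higher number from compound 1 to compound 3 (0.03 log units; within the scatter). For compound 3 the expected value is 20000 nM, with an estimated range of 8000 nM to 50000 nM.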

Compound 3, half-maximal inhibitory concentration: 13400 nM
For compound 3 the middle estimate is 1.5-fold (0.17 log units) above the measured one; the measured number falls inside the stated range.
By their numbers in this assay, from the lowest: compounds 2, 3 and 1 (each within the scatter of the next).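

In this assay, among these compounds, 2-cyanophenyl in place of 4-cyanophenyl on the nitrogen gives a 1.4-fold lower number from compound 1 to compound 3 (0.15 log units; within the scatter), the only measured step at this position. With the piperidin-1-yl chain held fixed, the two cyanophenyl groups cannot be told apart in this read-out. No measured evidence bears on this result.

As far as these compounds go, it remains open whether 2-cyanophenyl gives a similar number alongside the 4-methylpiperazin-1-yl group. From the compounds shown here alone, it is also open whether an amine or a carboxylic acid in place of the nitrile would give a step beyond the scatter.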